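A few compounds are considered here, and "the series" means these few. Any claim that something is new, unique, unknown or untested is made for them only; others in the source may bear on it.

Among the compounds with values here, compound 2 `O=c1cc(-c2ccccc2)oc2cc(OCc3ccccc3)c(OCCCCN3CCCCC3)c(O)c12` is the stronger of the two measured compounds in a functional assay on HepG2 cells (Homo sapiens) for antiproliferative activity, read by MTT assay, with a stated time of 48 h; on this read-out lower numbers stand for stronger inhibition and higher numbers for weaker inhibition: in this assay compound 2 gives 2400 nM, while compound 1 `O=c1cc(-c2ccccc2)oc2cc(O)c(OCCCN3CCCCC3)c(O)c12` gives 70600 nM, a gap well beyond the scatter of the method, with no other compound between them. Compound 3 `O=c1cc(-c2ccccc2)oc2cc(O)c(OCCCCN3CCCCC3)c(O)c12` has not yet been measured in this assay. It differs from compound 2 in one place only: hydrogen in place of benzyl on an oxygen on an aromatic ring, so that the benzyloxy group becomes a hydroxy group and the butyl chain carrying the piperidine is kept. Within the data shown here, no step between measured compounds isolates this change, since compound 1 carries a hydroxy at that place but also a shorter chain to the piperidine. Among the measured compounds shown here, the only guide is therefore the weak result of compound 1 in this assay, which points towards a rise in the number. On that basis the step from compound 2 to compound 3 is expected to be a 10-fold higher number from compound 2 to compound 3 (1.02 log units; beyond the scatter), a loss of activity larger than the scatter. Compound 3 is accordingly estimated at 25000 nM in this assay, with a plausible range from 6000 nM to 80000 nM.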

Compound 3, half-maximal inhibitory concentration: > 100000 nM
Compound 3 was reported as a limit (the forecaster's own chance of this, stated with the estimate: 10%); at least 4.0-fold (0.60 log units) between middle value and limit.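

In this assay compound 3 is reported only as a limit, not as a number: the limit of > 100000 nM in this assay, at which 1 of the 3 values shown sits.

Even as a floor, the change from benzyloxy to hydroxy with the butyl chain kept gives an at least 41-fold higher number from compound 2 to compound 3 (1.61 log units; beyond the scatter), the first step to isolate this position and to show that the benzyl on this oxygen carries much of the activity seen in compound 2. The step that lengthens the chain while the hydroxy group stays in place reads an at least 1.4-fold higher number from compound 1 to compound 3 (0.15 log units; that floor lies within the scatter); that floor lies within the scatter, so with a hydroxy group at this position the two compounds show no order by chain length.

On these data alone, it remains open whether a small group such as methyl or ethyl on this oxygen would recover any of the loss, or whether an aromatic ring such as that of the benzyl is needed there. As far as these compounds go, it also remains open how a shorter or longer chain would read with the benzyl kept, and whether a morpholine or a dimethylamine in place of the piperidine would change the number.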